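Working notes: carboxylic acid variant of compound 2

A few compounds are considered here, and "the series" means these few. Any claim that something is new, unique, unknown or untested is made for them only; others in the source may bear on it.

Measured so far in an assay on striatum with sodium-dependent dopamine transporter (Rattus norvegicus) as the target; a higher number here means a weaker inhibitor, a lower number a stronger inhibitor:
compound 1 `CN1CC[C@H](c2ccc(Cl)cc2)[C@@H](C(=O)OC(C)(C)C)C1` gives 318 nM;
compound 2 `C=CCOC[C@H]1CN(C)CC[C@@H]1c1ccc(Cl)cc1` gives 60 nM.

Going by the values given here, compound 2 holds the lowest of the two numbers in this assay; its only neighbour is compound 1, and the single measured step, a 5.3-fold lower number from compound 1 to compound 2 (0.72 log units; beyond the scatter), separates them. Compound 3 `CN1CC[C@H](c2ccc(Cl)cc2)[C@@H](CCC(=O)O)C1` is not yet measured. It differs from compound 2 by carboxymethyl in place of allyloxy on a saturated chain carbon bound to a saturated ring carbon. Among the compounds with values here, the one measured step bears on this only loosely: it exchanged a tert-butoxycarbonyl for an (allyloxy)methyl group on a saturated ring carbon and was modest in size. Within the data shown here, the change to compound 3 again removes the allyloxy part but introduces a carboxyl group, a kind of change for which no measured pair exists, so the direction cannot be read from the measured step alone. For compound 3 the expected step in this assay is upward, roughly an 8.3-fold higher number from compound 2 to compound 3 (0.92 log units; beyond the scatter), with wide uncertainty. The estimate for compound 3 in this assay is 500 nM, within a range of 120 nM to 2500 nM.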

Compound 3, inhibition constant: 1300 nM
Beside the measured number, compound 3's estimate is 2.6-fold (0.41 log units) below it, and the stated range covers the measured number.
By their numbers in this assay, from the lowest: compound 2; then compound 1; then compound 3.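

In this assay this position no longer moves in one direction only: the earlier change lowered the number, whereas a 22-fold higher number from compound 2 to compound 3 (1.34 log units; beyond the scatter) marks a large rise for carboxymethyl in place of allyloxy on a saturated chain carbon bound to a saturated ring carbon. The 2-carboxyethyl group also gives a higher number than tert-butoxycarbonyl on a saturated ring carbon, with a 4.1-fold higher number from compound 1 to compound 3 (0.61 log units; beyond the scatter) for that change, so compound 3 ranks weakest of the three, with its steps to both others printed as beyond the scatter. No supporting measurement bears on the reason for this rise.

The three compounds do not separate the contribution of the free carboxylic acid from that of the chain that carries it, since compound 3 alone has this group. On these data alone, the methyl ester of the same 2-carboxyethyl chain, a primary amide, and a longer carboxylic acid chain would each address part of that question, and whether a primary amine at the chain end behaves like the acid also remains open.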